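The compounds below may be only part of what the source reports. "The series", "measured", "known", "first", "only" and "open" are said of these compounds alone.

Series notes. Compound 1 `COc1ccc(-n2ccc(=O)c(C(=O)Nc3ccc(Oc4ccnc5[nH]ccc45)c(F)c3)n2)cc1` and compound 2 `O=C(Nc1ccc(Oc2ccnc3[nH]ccc23)c(F)c1)c1nn(-c2ccc(Br)cc2F)ccc1=O` share one core and differ only in the group on the aromatic nitrogen. In a functional assay on A549 cells (Homo sapiens) for cytotoxicity, read by MTT assay, with a stated time of 72 h (a higher number here means a weaker inhibitor, a lower number a stronger inhibitor), compound 1 gives > 60000 nM, which is a limit of the assay and not a number. In this assay, for the measured compounds named here, compound 2 gives 55700 nM, the only number so far in this assay. The other value, that of compound 1, is the limit of > 60000 nM in this assay, at which 1 of the 2 values shown sits. The step of an at least 1.0-fold lower number from compound 1 to compound 2 (0.03 log units; that floor lies within the scatter) lies within the scatter. Compound 3 `O=C(Nc1ccc(Oc2ccnc3[nH]ccc23)c(F)c1)c1nn(-c2ccc(Cl)c(C(F)(F)F)c2)ccc1=O` carries 4-chloro-3-(trifluoromethyl)phenyl in place of 4-bromo-2-fluorophenyl on an aromatic nitrogen. Going by the values given here, the one measured step bears on it, and it was within the scatter, so no shift beyond the scatter is expected in this assay for the step from compound 2 to compound 3; the estimated step is a 1.1-fold lower number from compound 2 to compound 3 (0.05 log units; within the scatter). Compound 3 is accordingly estimated at 50000 nM, with a range from 20000 nM to 120000 nM, and a limit rather than a number is a real possibility.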

Compound 3, half-maximal inhibitory concentration: 13400 nM
Beside the measured number, compound 3's estimate is 3.7-fold (0.57 log units) above it; measured number outside the range, below it.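

In this assay the group on the aromatic nitrogen now moves the read-out beyond the scatter, with a 4.2-fold lower number from compound 2 to compound 3 (0.62 log units; beyond the scatter), so this position is not indifferent to the group it carries. Against the 4-methoxyphenyl compound the same group gives an at least 4.4-fold lower number from compound 1 to compound 3 (0.65 log units; beyond the scatter), and that figure is only a floor. Compound 1 stays a limit of the assay and not a number: the limit of > 60000 nM in this assay, at which 1 of the 3 values shown sits.

The compounds shown do not separate the part of the trifluoromethyl from that of the chlorine, since both enter together and the bromine and fluorine leave together. Also open, going by these compounds, is whether a phenyl group carrying an amine or a carboxylic acid would keep, lose or extend this step in this assay.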